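Swapping fluoro for methyl on the oxime-bearing side ring

This account rests on a few compounds, and the source may have more. Where it says the series, first, only, none or still open, it means among the compounds named here.

Measured compounds:
Compound 1 `CO/N=C1/C(=O)N(CCCn2cc(CN3CCC[C@@H]4CN(c5c(F)cc6c(=O)c(C(=O)O)cn(C7CC7)c6c5OC)C[C@@H]43)nn2)c2ccc(F)cc21`: 4 ug/mL
Compound 2 `CCO/N=C1/C(=O)N(CCCn2cc(CN3CCC[C@@H]4CN(c5c(F)cc6c(=O)c(C(=O)O)cn(C7CC7)c6c5OC)C[C@@H]43)nn2)c2ccc(F)cc21`: 4 ug/mL
Compound 3 `COc1c(N2C[C@H]3CCCN(Cc4cn(CCCN5C(=O)C(=O)c6ccccc65)nn4)[C@H]3C2)c(F)cc2c(=O)c(C(=O)O)cn(C3CC3)c12`: 16 ug/mL

All three were tested in an ADME assay on Vero cells (Chlorocebus sabaeus) for cytotoxicity, read by MTT assay, with a stated time of 72 h; on this read-out higher numbers stand for lower toxicity in this test and lower numbers for higher toxicity in this test. Compound 1 gives 4 ug/mL, the same number at the digits shown as compound 2, and together these two give the lower number of the three. Within the data shown here, compound 3, which carries neither the oxime nor the fluoro on its side ring, stands at 16 ug/mL, a gap beyond the usual scatter; no single-point step links it to compound 1, so its value shows only that a compound of this family can score higher in this assay.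

Among the measured compounds shown here, the one measured step, no change at the digits printed from compound 1 to compound 2 (within the scatter), changed the chain on the oxime oxygen and left the number where it was.

Compound 4 `CO/N=C1/C(=O)N(CCCn2cc(CN3CCC[C@@H]4CN(c5c(F)cc6c(=O)c(C(=O)O)cn(C7CC7)c6c5OC)C[C@@H]43)nn2)c2ccc(C)cc21` is the next compound; it differs from compound 1 as follows: methyl in place of fluoro on an aromatic carbon. For the measured compounds named here, no measured step touches this ring or exchanges fluoro for methyl, so nothing here points in either direction. Going by the values given here, since the only step in this set, no change at the digits printed from compound 1 to compound 2 (within the scatter), was flat, the expectation for compound 4 in this assay is a step of about no change at the digits printed from compound 1 to compound 4 (within the scatter), that is, no change beyond the scatter. Compound 4 is therefore estimated at 4 ug/mL, with a range from 2 ug/mL to 10 ug/mL.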

Compound 4, half-maximal cytotoxic concentration: 8 ug/mL
The estimate for compound 4 lay 2.0-fold (0.30 log units) below the measured number; low and high end bracket the measured number.
By their numbers in this assay, from the lowest: compounds 1, 2, 4 and 3 (each within the scatter of the next, the first and the last beyond it).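

In this assay, methyl in place of fluoro on an aromatic carbon of the side ring gives a 2.0-fold higher number from compound 1 to compound 4 (0.30 log units; within the scatter), so this exchange cannot be told apart from repeat-measurement noise. Among these compounds, until now, the only single-place change available was on the chain of the oxime oxygen, no change at the digits printed from compound 1 to compound 2 (within the scatter); this new step is the first to reach the aromatic ring, and it shows that a fluoro and a methyl at this carbon can be exchanged without a change beyond the scatter in this cell test. No supporting measurement bears on why the number behaves this way.

The compounds shown leave open whether a larger change at this same carbon, such as an amine or a carboxylic acid in place of the fluoro, would take the number beyond the scatter. They also leave open whether a longer chain on the oxime oxygen, such as propyl, would stay as flat as the ethyl of compound 2 did, and whether it would do so with the methyl of compound 4 on the ring.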